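The source may report more compounds than this note shows. Statements on the series, on what has been measured and on what is new or still open speak of the compounds shown alone.

Of the compounds shown here, two sharing a trimethoxyphenyl-bearing core have been measured so far. In a functional assay on MCF7 cells (Homo sapiens) for cytotoxicity, read by MTT assay, with a stated time of 48 h (on this read-out higher numbers stand for weaker inhibition and lower numbers for stronger inhibition), compound 1 (`COc1cc(-n2c(-c3ccc(O)cc3)c[nH]c2=O)cc(OC)c1OC`) gives > 50000 nM, which is a limit of the assay and not a number. Compound 2 (`COc1cc(-n2c(-c3ccc([N+](=O)[O-])cc3)cn(C(C)=O)c2=O)cc(OC)c1OC`), with its 4-nitrophenyl and an acetyl group, gives > 50000 nM, likewise a limit. Compound 2 therefore has no numerical potency and stands at the limit of > 50000 nM in this assay, at which 2 of the 2 values shown sit.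

Compound 3 (`COc1ccc(-c2cn(C(C)=O)c(=O)n2-c2cc(OC)c(OC)c(OC)c2)cc1N`) keeps the acetyl group but carries 3-amino-4-methoxyphenyl in place of 4-nitrophenyl on an aromatic carbon. For the measured compounds named here, no measured step between two compounds shows what such an exchange does in this assay, so the expectation here is a judgement with wide uncertainty. A sizeable move toward stronger inhibition is expected, although another limit reading remains possible. The expected change is an at least 62-fold lower number from compound 2 to compound 3 (1.79 log units; beyond the scatter). For compound 3, the estimated half-maximal inhibitory concentration is 800 nM, with an expected range from 30 nM to 20000 nM.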

Compound 3, half-maximal inhibitory concentration: 43400 nM
Beside the measured number, compound 3's estimate is 54-fold (1.73 log units) below it, and the stated range ends below it.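

Compound 3 is the only compound shown so far with a real number in this assay: compound 3 gives 43400 nM, so this position, on an aromatic carbon of a five-membered aromatic ring with 2 nitrogen, now has a measurable reading with the acetyl group in place. Putting 3-amino-4-methoxyphenyl in place of 4-nitrophenyl gives an at least 1.1-fold lower number from compound 2 to compound 3 (0.06 log units; that floor lies within the scatter), so the change is secured only as a floor, and that floor does not show an effect beyond the scatter. Compound 2 remains a limit and not a number, so the true size of the step cannot be read, and most of the values shown still stand at that edge: the limit of > 50000 nM in this assay, at which 2 of the 3 values shown sit.

Open, going by these compounds, is whether the amine or the methoxy group accounts for the reading of compound 3, and whether either of them alone on that phenyl ring would give the same value. Also open, on these data alone, is what a longer acyl chain in place of the acetyl group, or a carboxylic acid on the phenyl ring, would do to the reading with the rest of compound 3 kept.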